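The source may hold more compounds than are shown below. What is called first, only, known or untested is meant among the compounds shown, and "the series" means these compounds.

Working notes on the series. In a functional assay on U-87MG ATCC cells (Homo sapiens) for cytotoxicity, read by MTT assay, with a stated time of 72 h (on this read-out higher numbers stand for weaker inhibition and lower numbers for stronger inhibition), compound 2 (`CN(C)CCn1cnnc1-c1cc(Oc2ccc(NC(=O)N/N=C/c3c(Cl)cccc3Cl)cc2F)ccn1`) gives > 100000 nM and that is a limit and not a number. Its place in the series is fixed only by that bound (the limit of > 100000 nM in this assay, at which 1 of the 3 values shown sits). Compound 1 (`CN(C)CCn1cnnc1-c1cc(Oc2ccc(NC(=O)N/N=C/c3ccc(Cl)cc3Cl)cc2F)ccn1`) gives 2330 nM in the same read-out, and compound 3 (`COc1ccc(OC)c(/C=N/NC(=O)Nc2ccc(Oc3ccnc(-c4nncn4CCN(C)C)c3)c(F)c2)c1`) gives 6400 nM there.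

Compound 4 (`CN(C)CCn1cnnc1-c1cc(Oc2ccc(NC(=O)N/N=C/c3ccccc3O[N+](=O)[O-])cc2F)ccn1`) carries 2-(nitrooxy)phenyl in place of 2,6-dichlorophenyl on a carbon with a double bond to nitrogen.

All three measured steps change this same group. Replacing 2,4-dichlorophenyl with 2,6-dichlorophenyl gave an at least 42-fold higher number from compound 1 to compound 2 (1.63 log units; beyond the scatter) and that step is large. Replacing 2,4-dichlorophenyl with 2,5-dimethoxyphenyl gave a 2.7-fold higher number from compound 1 to compound 3 (0.44 log units; beyond the scatter) and that step is modest. Going by the values given here, the closest precedent also removes 2,6-dichlorophenyl and gave an at least 15-fold lower number from compound 2 to compound 3 (1.19 log units; beyond the scatter) and that step is large.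

In this assay a large step to a lower number is therefore expected, estimated as an at least 16-fold lower number from compound 2 to compound 4 (1.22 log units; beyond the scatter) in size. The estimated value for compound 4 is 6000 nM and the expected range runs from 1500 nM to 30000 nM in this read-out.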

Compound 4, half-maximal inhibitory concentration: 7150 nM
Beside the measured number, compound 4's estimate is 1.2-fold (0.08 log units) below it; low and high end bracket the measured number.
By their numbers in this assay, from the lowest: compound 1; then compounds 3 and 4 (each within the scatter of the next). At a limit, above all of these: compound 2.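

In this assay, 2-(nitrooxy)phenyl on the carbon with a double bond to nitrogen gave an at least 13-fold lower number from compound 2 to compound 4 (1.14 log units; beyond the scatter), so a second group without chlorine in place of 2,6-dichlorophenyl also gives a measurable number, and the entering group need not be 2,5-dimethoxyphenyl. Replacing 2,5-dimethoxyphenyl with 2-(nitrooxy)phenyl gave a 1.1-fold higher number from compound 3 to compound 4 (0.05 log units; within the scatter), so these two different groups are not separated here, while replacing 2,4-dichlorophenyl gave a 3.1-fold higher number from compound 1 to compound 4 (0.49 log units; beyond the scatter), which leaves compound 1 with the lowest number of the four. Compound 2 still stands only as a limit and not a number: the limit of > 100000 nM in this assay, at which 1 of the 4 values shown sits.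

The compounds shown leave open how a plain phenyl, or a phenyl carrying an amine or a carboxylic acid, would read at this place. They also leave open whether any other group here would give a number lower than that of compound 1.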